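A pyrazole in place of phenyl: expectation for compound 4

The source may report more compounds than this note shows. Statements on the series, on what has been measured and on what is new or still open speak of the compounds shown alone.

Among the three measured compounds, compound 2 `Nc1ncnc2c1ncn2[C@@H]1O[C@H](CSCC[C@H](N)C(=O)NCc2ccccc2)[C@@H](O)[C@H]1O` stands with the highest number in an assay on Sf9 cells for inhibition of histone-lysine N-methyltransferase EZH2 (Homo sapiens), read by scintillation counting, in the presence of a further agent that is not named here (on this read-out lower numbers stand for stronger inhibition and higher numbers for weaker inhibition), giving 120000 nM. Compound 1 `Nc1ncnc2c1ncn2[C@@H]1O[C@H](CSCC[C@H](N)C(=O)NCC2CC2)[C@@H](O)[C@H]1O` gives 60000 nM, and compound 3 `CCn1cc(CNC(=O)[C@@H](N)CCSC[C@H]2O[C@@H](n3cnc4c(N)ncnc43)[C@H](O)[C@@H]2O)cn1` gives 50000 nM. Compound 4 `Nc1ncnc2c1ncn2[C@@H]1O[C@H](CSCC[C@H](N)C(=O)NCc2cc(C3CCC3)[nH]n2)[C@@H](O)[C@H]1O` differs from compound 2 by the change (a group of 9 heavy atoms (7 carbon, 2 nitrogen; one four-membered non-aromatic ring of carbon only, one five-membered aromatic ring with 2 hetero atoms) in place of a group of 6 heavy atoms (6 carbon; one six-membered aromatic ring of carbon only), on a saturated chain carbon bound to an amide-type nitrogen). Going by the values given here, two steps bear on this: a 2.0-fold higher number from compound 1 to compound 2 (0.30 log units; within the scatter), and a 2.4-fold lower number from compound 2 to compound 3 (0.38 log units; beyond the scatter). The second step, which also swaps phenyl for a five-membered aromatic ring with 2 hetero atoms, is the closer parallel and lies beyond the scatter, so a modest downward step is expected for compound 4, of about a 2.4-fold lower number from compound 2 to compound 4 (0.38 log units; beyond the scatter). Compound 4 is accordingly estimated at 50000 nM, with a range from 20000 nM to 150000 nM.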

Compound 4, half-maximal inhibitory concentration: 3000 nM
The estimate for compound 4 lay 17-fold (1.22 log units) above the measured number; measured number below the stated range.
By their numbers in this assay, from the lowest: compound 4; then compounds 3, 1 and 2 (each within the scatter of the next, the first and the last beyond it).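

In this assay, going by these compounds alone, the group on the saturated chain carbon bound to an amide-type nitrogen can move the number far more than the earlier compounds showed, with a 40-fold lower number from compound 2 to compound 4 (1.60 log units; beyond the scatter) and a 20-fold lower number from compound 1 to compound 4 (1.30 log units; beyond the scatter) and also a 17-fold lower number from compound 3 to compound 4 (1.22 log units; beyond the scatter). That last step has a five-membered aromatic ring with 2 hetero atoms on both sides, so this ring type alone does not bring the gain. Nothing available gives a reason for the gain.

The compounds shown leave open whether the four-membered ring of carbon or the ring's hydrogen-bond donor matters more. They also leave open how a tert-butyl group or an amine would fare in place of that four-membered ring.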